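The compounds below may be only part of what the source reports. "The series", "measured", "known", "first", "only" and "open" are said of these compounds alone.

Measured compounds in an ADME assay on the whole organism (Mus musculus, strain ICR) for pharmacokinetics, read by HPLC, with a stated time of 24 h, at a dose of 50 mg/kg by the oral route; on this read-out lower numbers stand for lower exposure and higher numbers for higher exposure at the dose given:
compound 1, `CCc1nc2ccc(Cl)cn2c1C(=O)NCCOc1ccc(N(C)C)cc1`, gives 3340 ng.h/mL
compound 2, `CCc1nc2ccc(Br)cn2c1C(=O)NCCOc1ccc(N2CCCCC2)cc1`, gives 818 ng.h/mL

Compound 2 stands lowest of the two numbers. Compound 1 lies above it by a gap that is beyond the usual scatter of this assay . Among the compounds with values here, the two compounds differ in more than one place, so their values show only that compound 1 reaches the higher exposure, not what carries the gap.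

Compound 3, `CCc1nc2ccc(Br)cn2c1C(=O)NCCOc1ccc(N2CCC(C(F)(F)F)CC2)cc1`, departs from compound 2 in one place: trifluoromethyl in place of hydrogen on a saturated ring carbon. Within the data shown here, no measured pair shows a change of this kind, so there is no yardstick for it. On that footing the step from compound 2 to compound 3 is expected to be small, a 1.2-fold lower number from compound 2 to compound 3 (0.07 log units; within the scatter), in no direction beyond the scatter. Compound 3 is estimated at 700 ng.h/mL in this assay , with a range from 250 ng.h/mL to 2000 ng.h/mL.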

Compound 3, area under the concentration-time curve: 7120 ng.h/mL
Compound 3: middle estimate off by 10-fold (1.01 log units), on the low side, and the stated range ends below it.
By their numbers in this assay, from the lowest: compound 2; then compound 1; then compound 3.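

In this assay the saturated ring carbon three ring bonds from the ring nitrogen turns out to matter for exposure: going from piperidin-1-yl to 4-(trifluoromethyl)piperidin-1-yl gives an 8.7-fold higher number from compound 2 to compound 3 (0.94 log units; beyond the scatter). This is the first difference among these compounds that can be tied to a single place, since the earlier pair differed in more than one and could not show what carried its gap. Nothing measured here explains why exposure moves with this change.

The compounds shown leave open whether the step belongs to trifluoromethyl itself or would also come with a methyl group, a single fluorine or a longer chain on the same carbon. They also leave open whether the same change would hold with chlorine in place of the bromine on the shared core.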